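Replacing the 4-chlorobenzyl group of compound 2

The source may report more compounds than this note shows. Statements on the series, on what has been measured and on what is new or still open speak of the compounds shown alone.

In an ADME assay on microsomes from liver (Mus musculus) for metabolic stability, with a stated time of 10 min, tested at 0.5 uM (a higher number here means that more of the compound is left, a lower number that less of the compound is left), compound 1 (`C[C@@H](CNc1ccc(Cl)cc1)[C@H]1CC[C@@H](c2ccnc3ccc(F)cc32)CC1`) gives 80% and compound 2 (`C[C@@H](NCc1ccc(Cl)cc1)[C@H]1CC[C@@H](c2ccnc3ccc(F)cc32)CC1`) gives 2% of the starting material. Going by the values given here, compound 2 is therefore the lower of the two numbers known so far, and by a wide margin.

Compound 3 (`C[C@@H](NC(=O)c1cccc(Cl)c1)[C@H]1CC[C@@H](c2ccnc3ccc(F)cc32)CC1`) keeps the shared core of compound 2 but carries (3-chlorophenyl)carbonyl in place of 4-chlorobenzyl on an amine nitrogen. Among the compounds with values here, no measured compound has a carbonyl at this place, so there is no direct precedent for the change.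

Within the data shown here, only one measured step bears on it, and it concerns the same part of the molecule. That step is a number 78 percentage points lower from compound 1 to compound 2 (beyond the scatter) and it is large, which shows that the number can swing widely when the surroundings of this nitrogen are altered. A fall is hardly possible because compound 2 stands at 2% already, so a rise is the likelier outcome.

The expected step is a number 43 percentage points higher from compound 2 to compound 3 (beyond the scatter) and its size is quite uncertain. In this assay compound 3 is estimated to give 45% (expected range 12% to 80%).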

Compound 3, percent of the compound remaining: 9%
Compound 3: middle estimate off by 36 percentage points, on the high side; the measured number lies below the stated range.
By their numbers in this assay, from the lowest: compounds 2 and 3 (each within the scatter of the next); then compound 1.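

In this assay, putting (3-chlorophenyl)carbonyl in place of 4-chlorobenzyl on the amine nitrogen gives a number 7 percentage points higher from compound 2 to compound 3 (within the scatter) and so does not separate the two compounds. The earlier step, a number 78 percentage points lower from compound 1 to compound 2 (beyond the scatter), showed how widely the number can swing around this nitrogen, whereas this result shows that not every change there has such an effect: adding a carbonyl, with its one hydrogen-bond acceptor, and moving the chlorine from the 4 to the 3 label of the name together leave compound 3 level with compound 2 within the scatter. Nothing among the data shown gives a reason for this outcome.

As far as these compounds go, since the carbonyl and the place of the chlorine changed in a single step, the part played by each remains open, and (4-chlorophenyl)carbonyl on the same nitrogen would separate the two. Also open, from the compounds shown here alone, is what a sulfonyl group or a urea on this nitrogen would give in this assay, and whether either would leave the number as low as in compound 2 and compound 3 or lift it clear of the scatter.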